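The source may report more compounds than this note shows. Statements on the series, on what has been measured and on what is new or still open speak of the compounds shown alone.

compound 1 `O=S(=O)(Nc1ccc(Br)c(Cl)c1)c1ccc(-c2cnc(C3CC3)o2)cc1` gives 491 nM
compound 2 `Cc1ccc(NS(=O)(=O)c2ccc(-c3cnc(C4CC4)o3)cc2)cc1C` gives 420 nM
compound 3 `O=S(=O)(Nc1cc(Cl)ccc1Cl)c1ccc(-c2cnc(C3CC3)o2)cc1` gives 1020 nM

These three compounds share a core and differ only in the group on a sulfonamide nitrogen. All were tested in a functional assay on cells (leukaemia cell line, Homo sapiens) for inhibition, read by sulforhodamine B assay, with a stated time of 48 h (on this read-out lower numbers stand for stronger inhibition of growth and higher numbers for weaker inhibition of growth), where compound 3 has the highest number and is therefore the weakest growth inhibitor of the set. The measurements show a 2.1-fold higher number from compound 1 to compound 3 (0.32 log units; beyond the scatter) and a 2.4-fold higher number from compound 2 to compound 3 (0.39 log units; beyond the scatter). The remaining comparison gives a 1.2-fold lower number from compound 1 to compound 2 (0.07 log units; within the scatter), so the two lower values cannot be ranked.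

Compound 4 `Cc1cc(Cl)cc(NS(=O)(=O)c2ccc(-c3cnc(C4CC4)o3)cc2)c1` has not yet been measured. It keeps the core of compound 3 and changes one group, with 3-chloro-5-methylphenyl in place of 2,5-dichlorophenyl on a sulfonamide nitrogen. Within the data shown here, no measured step makes exactly this swap, so the evidence is indirect and rests on only two comparisons. In both, moving away from the 2,5-dichlorophenyl group of compound 3 gave a lower number, with compound 1 at 491 nM and compound 2 at 420 nM. A modest step of similar size and direction is expected in this assay, and the estimated change is a 2.0-fold lower number from compound 3 to compound 4 (0.31 log units; beyond the scatter). For compound 4 the estimate is 500 nM, with an expected range from 250 nM to 1000 nM.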

Compound 4, concentration for 50% growth inhibition: 175 nM
Beside the measured number, compound 4's estimate is 2.9-fold (0.46 log units) above it, outside the stated range (below it).
By their numbers in this assay, from the lowest: compound 4; then compounds 2 and 1 (each within the scatter of the next); then compound 3.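

In this assay, the 3-chloro-5-methylphenyl group on the sulfonamide nitrogen gives a 5.8-fold lower number from compound 3 to compound 4 (0.77 log units; beyond the scatter), and it also improves on both of the better earlier groups, with a 2.4-fold lower number from compound 2 to compound 4 (0.38 log units; beyond the scatter) and a 2.8-fold lower number from compound 1 to compound 4 (0.45 log units; beyond the scatter). Compound 4 is therefore the strongest growth inhibitor of the four, showing that this position can go lower than the level shared by compounds 1 and 2, which could not be ranked against each other. The entering and leaving groups have equal counts of heavy atoms and neither has hydrogen-bond donors or acceptors, so these counts do not separate them, and nothing measured here says why the number falls.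

The compounds shown leave open which feature of the new group matters, since 3,5-dichlorophenyl and 3,5-dimethylphenyl would be needed to compare the chlorine and the methyl in the same arrangement. Going by these compounds, it is also open whether this position accepts an ethyl group, a longer chain, an amine or a carboxylic acid on the phenyl ring.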